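Fused bicyclic series: replacing the chain on the exocyclic amine

The source may report more compounds than this note shows. Statements on the series, on what has been measured and on what is new or still open speak of the compounds shown alone.

Compound 1 `N#CC1=C(NCN2CCCC2)N(c2ccccc2)C(=O)N2CCCCC(N3CCCC3)C12` and compound 2 `N#CC1=C(NCC(=O)N2CCCC2)N(c2ccccc2)C(=O)N2CCCCC(N3CCCC3)C12` share one core and differ only on the chain bound to the amine nitrogen. In a functional assay on the whole organism (strain albino) for inhibition, with Rattus norvegicus as the target, read by paw edema, with stated times of 1 h and 3 h, at a dose of 20 mmol/kg by the intraperitoneal route (a higher number here means a stronger effect of the compound at the dose given, a lower number a weaker effect), compound 1 gives 35.3%, and in this assay compound 2 gives 56%. Among the compounds with values here, the single step so far is a number 20.7 percentage points higher from compound 1 to compound 2 (beyond the scatter). Within the data shown here, compound 2 thus holds the higher of the two numbers, with compound 1 as its only neighbour and a gap beyond the scatter.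

Compound 3 `COc1ccc(N/C=N/C2=C(C#N)C3C(N4CCCC4)CCCCN3C(=O)N2c2ccccc2)cc1` replaces the whole chain: a group of 11 heavy atoms (8 carbon, 2 nitrogen, 1 oxygen; one six-membered aromatic ring of carbon only) in place of a group of 9 heavy atoms (6 carbon, 2 nitrogen, 1 oxygen; one five-membered non-aromatic ring with 1 hetero atom), on a double-bonded ring carbon. Among the measured compounds shown here, the one measured step concerns a change within the chain, (pyrrolidin-1-yl)carbonyl for pyrrolidin-1-yl on a saturated chain carbon, whereas the change to compound 3 removes that chain and brings in a group with a six-membered aromatic ring of carbon only and a double bond outside aromatic rings. For the measured compounds named here, no measured step tests a change of this kind, so the direction is unsettled; the expected outcome for a number 11 percentage points lower from compound 2 to compound 3 (beyond the scatter) is a step that may fall on either side of the scatter. Compound 3 is therefore estimated at 45%, with a range from 20% to 70%.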

Compound 3, a percentage reported as inhibition, in the whole organism at one dose (the size of the read-out at that dose, not a potency): 50.2%
Compound 3: middle estimate off by 5.2 percentage points, on the low side; the range from low to high includes it.
By their numbers in this assay, from the lowest: compound 1; then compounds 3 and 2 (each within the scatter of the next).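

In this assay, the double-bonded ring carbon takes an exchange of the whole group, not only a change within the chain: the result is a number 5.8 percentage points lower from compound 2 to compound 3 (within the scatter), so the group with a six-membered aromatic ring of carbon only stands level with (((pyrrolidin-1-yl)carbonyl)methyl)amino at the dose given. Set against the chain of compound 1, the same group gives a number 14.9 percentage points higher from compound 1 to compound 3 (beyond the scatter), which leaves compound 1 with the lowest number of the three and shows that a read-out at this level does not depend on the five-membered non-aromatic ring of the group that leaves. Nothing at hand explains why two such different groups give numbers within the scatter of each other.

The compounds shown leave open whether a plain amino group, a longer chain ending in a carbonyl, or an unsubstituted phenyl ring on the same carbon would hold this level. They also leave open how far the read-out depends on the pyrrolidin-1-yl group on the fused ring, which all three compounds carry, and, with a single dose, they give no measure of potency.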